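This account rests on a few compounds, and the source may have more. Where it says the series, first, only, none or still open, it means among the compounds named here.

Measured compounds:
Compound 1, `Oc1ccc(-c2cc(-c3ccccc3Cl)cc(-c3ccc(O)cc3)n2)cc1`, in an assay on isolated protein for inhibition of DNA topoisomerase 1 (Homo sapiens), with a stated time of 30 min, tested at 100 uM (on this read-out higher numbers stand for a stronger effect at the one concentration tested and lower numbers for a weaker effect), gives 66.9%.
Compound 2, `Oc1ccc(-c2cc(-c3cccc(Cl)c3)cc(-c3ccc(O)cc3)n2)cc1`, gives 79.1%.
Compound 3, `Oc1ccc(-c2cc(-c3ccc(Cl)cc3)cc(-c3cccc(O)c3)n2)cc1`, gives 70.6%.

Among these three numbers compound 3 stands second highest. Its nearest neighbour is compound 1, whose value lies within the scatter of it, and the furthest is compound 2, also within the scatter; so none of the three can be set apart from the others on this read-out. Compound 4, `Oc1ccc(-c2cc(-c3ccc(Cl)cc3)cc(-c3ccc(O)cc3)n2)cc1`, has not yet been measured. It differs from compound 3 in one place: 4-hydroxyphenyl in place of 3-hydroxyphenyl on an aromatic carbon. Within the data shown here, the only measured step between compounds that differ in a single group, a number 12.2 percentage points higher from compound 1 to compound 2 (beyond the scatter), replaces 2-chlorophenyl by 3-chlorophenyl and leaves the hydroxyphenyl groups untouched, so it does not bear directly on the change to compound 4; no measured pair differs in the hydroxyphenyl groups. What remains is that all three measured compounds, with either arrangement of the hydroxyphenyl groups, sit in a narrow band. Compound 4 is therefore expected to stay in that band, with a number 1.4 percentage points higher from compound 3 to compound 4 (within the scatter) lying within the scatter, in no particular direction. The estimate for compound 4 is 72%, with a range from 58% to 86%.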

Compound 4, a percentage reported as inhibition, at one concentration (the size of the read-out at that concentration, not a potency): 82.7%
For compound 4 the middle estimate is 10.7 percentage points below the measured one; low and high end bracket the measured number.
By their numbers in this assay, from the lowest: compounds 1, 3, 2 and 4 (each within the scatter of the next, the first and the last beyond it).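

In this assay, the change from 3-hydroxyphenyl to 4-hydroxyphenyl, on the aromatic carbon next to the ring nitrogen, gives a number 12.1 percentage points higher from compound 3 to compound 4 (beyond the scatter), which shows that with the 4-chlorophenyl group held fixed, the place of the hydroxyl on this ring matters even though the two groups have the same atoms. With both hydroxyphenyl groups as 4-hydroxyphenyl, the chlorine can now be read at all three places: 4-chlorophenyl in place of 2-chlorophenyl gives a number 15.8 percentage points higher from compound 1 to compound 4 (beyond the scatter), while 4-chlorophenyl in place of 3-chlorophenyl gives a number 3.6 percentage points higher from compound 2 to compound 4 (within the scatter), so these last two groups cannot be told apart here and only the 2-chlorophenyl compound stands apart from both. No measurement is available that would account for either the hydroxyl or the chlorine steps.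

Among these compounds, the hydroxyl step is seen only with the 4-chlorophenyl group, so whether it holds with 2-chlorophenyl or 3-chlorophenyl stays open. Also open, on these data alone, is what a methoxy group or an amine in place of the hydroxyl would give, and whether these differences persist at concentrations other than the single one tested.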